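Replacing One Halophenyl by Another on the Aromatic Nitrogen

The source may report more compounds than this note shows. Statements on the series, on what has been measured and on what is new or still open speak of the compounds shown alone.

Compound 1 `C=CCc1cc(O)c(O)c(CN2CCC(CO)CC2)c1` gives 5.4% in a functional assay on HepG2 cells (Homo sapiens) for inhibition, read by MTT assay, with a stated time of 72 h, tested at 50 uM; a lower number here means less inhibition of growth, a higher number more inhibition of growth at the concentration tested.
Compound 2 `C=CCc1ccc(OCc2cn(-c3ccccc3Cl)nn2)c(O)c1` gives 4.7% in this assay.
Compound 3 `C=CCc1cc(O)c(O)c(CN2CCC(CCO)CC2)c1` gives 2% in this assay.

All three numbers are low, and compound 2 stands close to both compound 1 and compound 3, each within the scatter. Among the measured compounds shown here, the only step between measured pairs, a number 3.4 percentage points lower from compound 1 to compound 3 (within the scatter), concerns the saturated chain on the shared core of compound 1 and says nothing about the aromatic ring carried on the aromatic nitrogen. Compound 4 `C=CCc1ccc(OCc2cn(-c3ccc(Br)cc3)nn2)c(O)c1` is compound 2 with 4-bromophenyl in place of 2-chlorophenyl on an aromatic nitrogen. For the measured compounds named here, no measured pair varies this group, so no step bears on it; the sole guide is that every compound so far barely inhibits growth at the concentration tested. The expected change is a number 0.3 percentage points higher from compound 2 to compound 4 (within the scatter), staying within the scatter. The estimate for compound 4 is 5%, ranging from -5% to 15%.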

Compound 4, percent growth inhibition at one concentration: 9.5%
Beside the measured number, compound 4's estimate is 4.5 percentage points below it; the measured number falls inside the stated range.
By their numbers in this assay, from the lowest: compounds 3, 2, 1 and 4 (each within the scatter of the next).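

Among the compounds shown here, the exchange of 2-chlorophenyl for 4-bromophenyl on an aromatic nitrogen gives a number 4.8 percentage points higher from compound 2 to compound 4 (within the scatter) in this assay and is the first step read at this position. Both the halogen and its place on the phenyl ring differ in this step, and it cannot separate the two. No available evidence accounts for the result.

Open, on these data alone, is what 4-chlorophenyl would give at this position, with the place of compound 4 and the halogen of compound 2. Also open, as far as these compounds go, is whether an aminophenyl or a carboxylic acid on the phenyl ring would move growth inhibition beyond the scatter.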